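A few compounds are considered here, and "the series" means these few. Any claim that something is new, unique, unknown or untested is made for them only; others in the source may bear on it.

Measured in a functional assay on HCT-116 cells (Homo sapiens) for antiproliferative activity, read by MTT assay, with a stated time of 72 h; a higher number here means a weaker inhibitor, a lower number a stronger inhibitor:
Compound 1 `O=C(CCc1cccc2c1B(O)OC2)Nc1ccc(F)cc1`: 650 nM
Compound 2 `O=C(CCc1cccc2c1B(O)OC2)Nc1ccc(Cl)cc1`: 12000 nM
Compound 3 `C#Cc1ccc(NC(=O)CCc2cccc3c2B(O)OC3)cc1`: 45000 nM

Compound 3 has the highest number of the three and is the weakest inhibitor among them. Compound 4 `CC(C)(C)OC(=O)NCc1ccc(NC(=O)CCc2cccc3c2B(O)OC3)cc1` carries ((tert-butoxycarbonyl)amino)methyl in place of ethynyl on an aromatic carbon, para to a large group: ((tert-butoxycarbonyl)amino)methyl in place of ethynyl on an aromatic carbon. Three measured steps at this place bear on the change: two large ones, an 18-fold higher number from compound 1 to compound 2 (1.27 log units; beyond the scatter) and a 69-fold higher number from compound 1 to compound 3 (1.84 log units; beyond the scatter), and a modest one, a 3.8-fold higher number from compound 2 to compound 3 (0.57 log units; beyond the scatter). None involves a group like the entering one, so the direction is uncertain. A modest step to a lower number in this assay is expected because compound 3 already stands at 45000 nM, the top of the measured range. The expected change is a 3.0-fold lower number from compound 3 to compound 4 (0.48 log units; beyond the scatter). For compound 4 the estimate is 15000 nM, with an expected range from 2500 nM to 60000 nM.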

Compound 4, half-maximal inhibitory concentration: 2300 nM
Estimate against measurement, compound 4: 6.5-fold (0.81 log units) above; measured number outside the range, below it.
By their numbers in this assay, from the lowest: compound 1; then compound 4; then compound 2; then compound 3.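

In this assay, ((tert-butoxycarbonyl)amino)methyl on this aromatic carbon gives a 20-fold lower number from compound 3 to compound 4 (1.29 log units; beyond the scatter) and a 5.2-fold lower number from compound 2 to compound 4 (0.72 log units; beyond the scatter), so a group of 9 heavy atoms is accepted at this place. With a 3.5-fold higher number from compound 1 to compound 4 (0.55 log units; beyond the scatter), fluoro still gives the lower number, but compound 4 goes against any reading of compounds 1, 2 and 3 in which the number simply rises as the group grows. Nothing measured here accounts for this change. The compounds shown leave open whether the tert-butoxycarbonyl part is needed or whether a free aminomethyl group would give a similar number.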